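Swapping Cyclopentyl for Tert-Butyl Without a Measured Baseline

The compounds below may be only part of what the source reports. "The series", "measured", "known", "first", "only" and "open" are said of these compounds alone.

Three related compounds have been taken through an ADME assay on the whole organism (plasma, Rattus norvegicus, strain Sprague-Dawley) for pharmacokinetics, read by LC-MS, with a stated time of 4 h, at a dose of 15 mg/kg by the intraduodenal route; a higher number here means more compound in the circulation at the dose given, a lower number less compound in the circulation. In this test, compound 1 `C=C[C@@H]1C[C@]1(NC(=O)[C@@H]1C[C@@H](Oc2nccc3cc(OC)ccc23)CN1C(=O)[C@@H](NC(=O)N[C@H](C(=O)O)C(C)(C)C)C(C)(C)C)C(=O)NS(=O)(=O)C1CC1` gives 91 ng.h/mL, while compound 2 `C=C[C@@H]1C[C@]1(NC(=O)[C@@H]1C[C@@H](Oc2cc(-c3ccccc3)nc3cc(OC)ccc23)CN1C(=O)[C@@H](NC(=O)NC(C)(C)C)C(C)(C)C)C(=O)NS(=O)(=O)C1CC1` gives a clearly lower 17 ng.h/mL. Compound 3 `C=C[C@@H]1C[C@]1(NC(=O)[C@@H]1C[C@@H](Oc2cc(-c3ccccc3)nc3cc(OC)ccc23)CN1C(=O)[C@H]([C@@H](C)CC)N(C)C(=O)NC1CCCC1)C(=O)NS(=O)(=O)C1CC1` offers no number to start from, as its result reads "not determined" (no result reported), so it cannot be placed relative to the other two.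

The compound still awaiting measurement is compound 4 `C=C[C@@H]1C[C@]1(NC(=O)[C@@H]1C[C@@H](Oc2cc(-c3ccccc3)nc3cc(OC)ccc23)CN1C(=O)[C@H]([C@@H](C)CC)N(C)C(=O)NC(C)(C)C)C(=O)NS(=O)(=O)C1CC1`. The structural change is tert-butyl in place of cyclopentyl on an amide-type nitrogen, with tert-butyl in place of cyclopentyl on an amide-type nitrogen. With no value for compound 3, the size of this step cannot be anchored, so no step beyond the usual scatter is expected in either direction. The nearest guide is compound 2, which also carries tert-butyl on an amide-type nitrogen and gives 17 ng.h/mL, so a low exposure seems the more likely outcome. Compound 4 is expected to reach about 25 ng.h/mL, with an estimated range of 6 ng.h/mL to 100 ng.h/mL.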

Compound 4, area under the concentration-time curve: 16 ng.h/mL
The estimate for compound 4 lay 1.6-fold (0.19 log units) above the measured number; low and high end bracket the measured number.
By their numbers in this assay, from the lowest: compounds 4 and 2 (each within the scatter of the next); then compound 1.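

In this assay compound 4 gives 16 ng.h/mL, but compound 3 has no number, so the change from cyclopentyl to tert-butyl between them cannot be read as a step. As far as these compounds go, what that swap alone does to exposure stays open, and no supporting data bear on this result.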